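Dropping the methyl group of compound 1

This account rests on a few compounds, and the source may have more. Where it says the series, first, only, none or still open, it means among the compounds named here.

Compound 1 `Cc1ccc([C@]2(CO)NC[C@@H](O)[C@@H]2O)cc1` stands lowest of the three compounds measured in an assay on isolated protein for inhibition of tissue alpha-L-fucosidase (Bos taurus), tested at 1000 uM (on this read-out higher numbers stand for more inhibition at the one concentration tested (going by the name of the read-out) and lower numbers for less inhibition), where compound 1 gives 0%. Its nearest neighbour is compound 3 `COc1cccc([C@@]2(CO)NC[C@H](O)[C@H]2O)c1`, which gives 1.6% in this assay, and the furthest is its mirror image, compound 2 `Cc1ccc([C@@]2(CO)NC[C@H](O)[C@H]2O)cc1`, which gives 3.3% in this assay. Both gaps to compound 1 lie within the scatter, so the three numbers cannot be told apart. Among the measured compounds shown here, the only step between compounds differing in one place is a number 3.3 percentage points higher from compound 1 to compound 2 (within the scatter), which goes with the fact that compounds 1 and 2 differ only in the configuration as drawn and shows that inverting every stereocentre of this core leaves the read-out essentially unchanged.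

Compound 4 `OC[C@@]1(c2ccccc2)NC[C@@H](O)[C@@H]1O` differs from compound 1 by hydrogen in place of methyl on an aromatic carbon. For the measured compounds named here, no measured step concerns such a change, so nothing tells how it acts on its own. What the measured compounds show is that three variants of this core all sit at the floor of this assay. Compound 4 is therefore expected to behave alike, with a step of a number 2 percentage points higher from compound 1 to compound 4 (within the scatter) that stays within the scatter. The estimate for compound 4 in this assay is 2%, expected to fall between 0% and 10%.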

Compound 4, a percentage reported as inhibition, at one concentration (the size of the read-out at that concentration, not a potency): 0%
Compound 4: the middle estimate sits 2 percentage points above what was measured, and the stated range covers the measured number.
By their numbers in this assay, from the lowest: compounds 1, 4, 3 and 2 (each within the scatter of the next).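

Hydrogen in place of methyl on this aromatic carbon comes with no change at the digits printed from compound 1 to compound 4 (within the scatter) in this assay, and this is the only measured step that concerns this position. Where the step between compounds 1 and 2 spoke only to configuration, this one speaks to the group itself: with or without the methyl group, this configuration of the shared core stays at the floor of the read-out at the one concentration tested, so the methyl group is not what holds compound 1 there. None of the information available gives a reason why the change leaves the read-out where it was.

As far as these compounds go, since compound 1 already starts at the floor, the step cannot show whether the methyl group contributes anything that a more responsive compound would reveal, and the hydrogen counterpart in the mirror-image configuration of compound 2 remains open. Also open, from the compounds shown here alone, is whether a larger or different group on the same aromatic carbon, such as an amine, a carboxylic acid or a longer chain, would lift the core of compound 1 off the floor in this assay.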